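Methoxy for Methyl: Estimating Compound 4

The source may hold more compounds than are shown below. What is called first, only, known or untested is meant among the compounds shown, and "the series" means these compounds.

Among the three measured compounds, compound 3 `Cc1ccc(S(=O)(=O)Nc2cncc(-c3cnc(N)nc3)c2)cc1` carries the lowest number in an assay on isolated protein for binding affinity to phosphatidylinositol 4,5-bisphosphate 3-kinase catalytic subunit beta isoform (Homo sapiens) (a lower number here means tighter binding, a higher number weaker binding), where compound 3 gives 100 nM. Compound 1 `Nc1ncc(-c2cncc(NS(=O)(=O)c3ccccc3)c2)cn1` gives 360 nM in this assay, and the step of a 3.6-fold lower number from compound 1 to compound 3 (0.56 log units; beyond the scatter) shows the gain from adding the methyl. Compound 2 `Cc1ccc(S(=O)(=O)Nc2cncc(-c3cnc(N)nc3)c2)cc1[N+](=O)[O-]` gives 250 nM, and the step of a 2.5-fold lower number from compound 2 to compound 3 (0.40 log units; beyond the scatter) shows the gain from removing the nitro group. Compound 4 `COc1ccc(S(=O)(=O)Nc2cncc(-c3cnc(N)nc3)c2)cc1` differs from compound 3 by methoxy in place of methyl on an aromatic carbon. Among the measured compounds shown here, of the two measured steps, only the step from compound 1 to compound 3 touches the methyl that now gives way, and it was modest; no measured compound carries a methoxy group, so the direction of the new step cannot be read from the data. Both measured steps being modest, compound 4 is expected to land near compound 3, with a step of a 1.2-fold higher number from compound 3 to compound 4 (0.08 log units; within the scatter) that is expected to stay within the scatter. Compound 4 is estimated at 120 nM, in a range from 45 nM to 320 nM.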

Compound 4, dissociation constant: 500 nM
Compound 4: the middle estimate sits 4.2-fold (0.62 log units) below what was measured; the whole stated range lies below it.
By their numbers in this assay, from the lowest: compound 3; then compounds 2, 1 and 4 (each within the scatter of the next).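

The earlier compounds shown here showed only that methyl on this aromatic carbon, para to a large group, gives a lower number than hydrogen. Methoxy in place of methyl gives a 5.0-fold higher number from compound 3 to compound 4 (0.70 log units; beyond the scatter) in this assay and thus shows that the gain at this position does not extend to every group placed there. Methoxy in place of hydrogen gives a 1.4-fold higher number from compound 1 to compound 4 (0.14 log units; within the scatter), so the gain seen with methyl is not seen with methoxy, and no supporting data bear on why the two groups differ here.

The compounds shown leave open whether an ethyl group or a chlorine atom at this position would match compound 3 at 100 nM or follow methoxy instead. They also leave open how a hydroxyl group or an amine would compare with methoxy on the same carbon.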